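Two Fluorines Leave a Compound Already Showing No Inhibition

The source may report more compounds than this note shows. Statements on the series, on what has been measured and on what is new or still open speak of the compounds shown alone.

Compound 1 `Cc1c(/C=N\O)cc(-c2ccc(S(C)(=O)=O)cc2)n1-c1ccccc1` and compound 2 `Cc1c(C#N)cc(-c2ccc(S(C)(=O)=O)cc2)n1-c1ccc(F)c(F)c1` were both tested in an assay on J774 cells for inhibition of prostaglandin G/H synthase 1 (Mus musculus), read by immunoassay, with stated times of 15 min and 30 min; on this read-out higher numbers stand for weaker inhibition and lower numbers for stronger inhibition. Compound 1 returns only the limit of > 10000 nM. Compound 2 likewise returns only the limit of > 10000 nM. Compound 2 thus stands at the top of the numbers shown, where (the limit of > 10000 nM in this assay, at which 2 of the 2 values shown sit). Compound 3 `Cc1c(C#N)cc(-c2ccc(S(C)(=O)=O)cc2)n1-c1ccccc1` differs from compound 2 in one place: phenyl in place of 3,4-difluorophenyl on an aromatic nitrogen. Going by the values given here, no measured pair isolates this change, so no step can be sized from data. The expected step that the limit leaves unreadable from compound 2 to compound 3 is none beyond the scatter. This expectation rests on compound 1, which also carries phenyl on an aromatic nitrogen and gives > 10000 nM. Compound 3 is therefore expected at 20000 nM, within 8000 nM to 60000 nM, most likely again only as a limit.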

Compound 3, half-maximal inhibitory concentration: > 10000 nM
Compound 3: no number, only a limit (the forecaster's own chance of this, stated with the estimate: 85%); the middle value does not contradict the limit.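

Compound 1, compound 2 and compound 3 all give only limits in this assay, so neither step to compound 3 can be read. The compounds shown leave open whether phenyl and 3,4-difluorophenyl differ at all, as all three share one limit: the limit of > 10000 nM in this assay, at which 3 of the 3 values shown sit.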